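The source may report more compounds than this note shows. Statements on the series, on what has been measured and on what is new or still open speak of the compounds shown alone.

Of the compounds shown here, three built on one shared core have been tested in an ADME assay on L02 cells (Homo sapiens) for antiproliferative activity, read by MTT assay, with a stated time of 48 h; on this read-out lower numbers stand for stronger inhibition and higher numbers for weaker inhibition. Compound 1 `Cc1cccc(-n2nncc2CN2C(=O)C3(C(C#N)=C(N)Oc4c(N)cc5nc6ccccc6nc5c43)c3ccccc32)c1` carries a 3-methylphenyl group on an aromatic nitrogen; in this assay compound 1 reaches only the limit of the assay, > 50000 nM. Compound 2 `COc1ccc(-n2nncc2CN2C(=O)C3(C(C#N)=C(N)Oc4c(N)cc5nc6ccccc6nc5c43)c3ccccc32)cc1` carries a 4-methoxyphenyl group in that place; in this assay compound 2 likewise stops at the limit, > 50000 nM. Compound 3 `Cc1cc(C)cc(-n2nncc2CN2C(=O)C3(C(C#N)=C(N)Oc4c(N)cc5nc6ccccc6nc5c43)c3ccccc32)c1` carries a 3,5-dimethylphenyl group; in this assay compound 3 also gives only a limit, > 50000 nM. Among the compounds with values here, compound 3 thus stands where every value so far stands, at the limit described as the limit of > 50000 nM in this assay, at which 3 of the 3 values shown sit. Since all three numbers are limits, the steps between them have no readable size: a step that the two limits leave unreadable from compound 1 to compound 2, a step that the two limits leave unreadable from compound 1 to compound 3 and a step that the two limits leave unreadable from compound 2 to compound 3.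

Compound 4 `COc1cc(-n2nncc2CN2C(=O)C3(C(C#N)=C(N)Oc4c(N)cc5nc6ccccc6nc5c43)c3ccccc32)c(OC)cc1Cl` differs from compound 3 in one place: 4-chloro-2,5-dimethoxyphenyl in place of 3,5-dimethylphenyl on an aromatic nitrogen. Each measured step exchanged one aryl group on the same nitrogen for another, and none brought the value inside the measurable range, so no step beyond the scatter is expected here, and the most likely outcome for compound 4 is another limit. In this assay the expected step is a step that the limit leaves unreadable from compound 3 to compound 4. Compound 4 is therefore estimated at 70000 nM, with a range from 30000 nM to 250000 nM.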

Compound 4, half-maximal inhibitory concentration: > 50000 nM
Compound 4 gave a limit, no number (the forecaster's own chance of this, stated with the estimate: 85%); the middle value does not contradict the limit.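

In this assay compound 4 gives > 50000 nM, which is a limit and not a number. Within the data shown here, no step from compound 1, compound 2 or compound 3 to compound 4 can be read, and all four sit together: the limit of > 50000 nM in this assay, at which 4 of the 4 values shown sit. The compounds shown leave open how these four aryl groups truly compare, and whether any other aryl group on this nitrogen would give a measurable value.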